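Piperazine aryl swap in a sulfonamide antagonist series

The compounds below may be only part of what the source reports. "The series", "measured", "known", "first", "only" and "open" are said of these compounds alone.

Measured so far:
Compound 1, `CC(C(=O)NCc1ccc(C(F)(F)F)nc1N1CCC(=O)CC1)c1ccc(NS(C)(=O)=O)c(F)c1`, in a functional assay on CHO-K1 cells for antagonist activity at transient receptor potential cation channel subfamily V member 1 (Homo sapiens), read by FLIPR (on this read-out lower numbers stand for stronger inhibition and higher numbers for weaker inhibition), gives 91 nM.
Compound 2, `Cc1cccc(N2CCN(c3nc(C(F)(F)F)ccc3CNC(=O)C(C)c3ccc(NS(C)(=O)=O)c(F)c3)CC2)c1`, in this assay gives 3.4 nM.

For the measured compounds named here, compound 2 stands at the lowest number of the two, with compound 1 as its only neighbour at a clearly higher number, beyond the usual scatter. Compound 3, `CC(C(=O)NCc1ccc(C(F)(F)F)nc1N1CCN(c2ncccc2C(F)(F)F)CC1)c1ccc(NS(C)(=O)=O)c(F)c1`, has not yet been measured. It differs from compound 2 in one place: 3-(trifluoromethyl)pyridin-2-yl in place of 3-methylphenyl on an amine nitrogen in a ring. No step between two measured compounds covers a change of this kind, so the expectation rests on the fact that compound 2 already sits at the low end of what is shown. The step from compound 2 to compound 3 in this assay is expected to be small, estimated as a 1.5-fold higher number from compound 2 to compound 3 (0.17 log units; within the scatter), in either direction or none beyond the scatter. Compound 3 is therefore estimated at 5 nM, with a likely range from 1.5 nM to 20 nM.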

Compound 3, inhibition constant: 2.8 nM
The estimate for compound 3 lay 1.8-fold (0.25 log units) above the measured number, and the stated range covers the measured number.
By their numbers in this assay, from the lowest: compounds 3 and 2 (each within the scatter of the next); then compound 1.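

In this assay, 3-(trifluoromethyl)pyridin-2-yl in place of 3-methylphenyl on an amine nitrogen in a ring gives a 1.2-fold lower number from compound 2 to compound 3 (0.08 log units; within the scatter) and so leaves the two compounds indistinguishable. For the compounds shown here, of the earlier compounds, only compound 2 carried an aromatic ring at this position, and compound 3 shows that a second kind is accepted there, one with 1 hetero atom, more heavy atoms than 3-methylphenyl and 1 hydrogen-bond acceptor, with no step beyond the scatter. Nothing at hand explains why the two groups read alike.

The compounds shown leave open how the ring nitrogen and the trifluoromethyl count separately, which 3-methylpyridin-2-yl or 3-(trifluoromethyl)phenyl on the same nitrogen would address. They also leave open whether an aromatic ring is needed there at all, which a cyclohexyl group could test.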